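The source may hold more compounds than are shown below. What is called first, only, known or untested is meant among the compounds shown, and "the series" means these compounds.

Compound 1 `Cc1ccc(-c2nc(=O)o[nH]2)c(-c2ccc([C@@H](C)N(CC3CC3)c3nc(C(=O)NS(=O)(=O)C4CC4)c(C4CC4)s3)cc2)c1` and compound 2 `CONC(=O)c1ccc(Cl)cc1-c1ccc([C@@H](C)N(CC2CC2)c2nc(C(=O)NS(=O)(=O)C3CC3)c(C3CC3)s2)cc1` were each examined in an ADME assay on the whole organism (Macaca fascicularis) for metabolic stability, at a dose of 0.3 mg/kg by the oral route; on this read-out higher numbers stand for a longer-lived compound and lower numbers for a shorter-lived compound. In this assay compound 1 gives 3.3 h. Compound 2 gives 3.3 h, level with compound 1 at the digits shown and within the scatter. Compound 3 `CNC(=O)c1ccc(Cl)cc1-c1ccc([C@@H](C)N(CC2CC2)c2nc(C(=O)NS(=O)(=O)C3CC3)c(C3CC3)s2)cc1` differs from compound 2 in a single place, methyl in place of methoxy on an amide-type nitrogen. Within the data shown here, no measured pair shows this change, so in this assay a step of the size a 1.1-fold lower number from compound 2 to compound 3 (0.04 log units; within the scatter) is expected, within the scatter and in no fixed direction. Compound 3 is therefore estimated at 3 h, with a range from 1.5 h to 6 h.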

Compound 3, half-life: 3.6 h
For compound 3 the middle estimate is 1.2-fold (0.08 log units) below the measured one, within the range that was stated.
By their numbers in this assay, from the lowest: compounds 1, 2 and 3 (each within the scatter of the next).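

Methyl in place of methoxy on the amide-type nitrogen gives a 1.1-fold higher number from compound 2 to compound 3 (0.04 log units; within the scatter) in this assay and is the only single-place change shown, so at this position the two groups cannot be told apart on this read-out. The compounds shown offer no measurement that bears on why this is so.

They leave open whether a longer chain such as ethyl on this nitrogen, or a carboxylic acid in place of the methylcarbamoyl group, would also stay within the scatter of compound 3.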